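Series notes: 2,5-dichlorobenzyl to 4-(trifluoromethyl)benzyl

This account rests on a few compounds, and the source may have more. Where it says the series, first, only, none or still open, it means among the compounds named here.

In a toxicity assay on GES1 cells (Homo sapiens) for inhibition, read by MTT assay, with a stated time of 72 h (on this read-out lower numbers stand for stronger inhibition and higher numbers for weaker inhibition), compound 1 `Cc1cc(N2CC[C@@H](C)[C@@H](N(C)c3ncnc4[nH]ccc34)C2)n2nc(SCc3ccc(F)c(Cl)c3)nc2n1` reads > 100000 nM, which is a limit of the assay and not a number. Among the measured compounds shown here, compound 2 `Cc1cc(N2CC[C@@H](C)[C@@H](N(C)c3ncnc4[nH]ccc34)C2)n2nc(SCc3cc(Cl)ccc3Cl)nc2n1` reads 87500 nM, the only true number so far in this small set, so it has no numeric neighbour to be ranked against.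

Compound 3 `Cc1cc(N2CC[C@@H](C)[C@@H](N(C)c3ncnc4[nH]ccc34)C2)n2nc(SCc3ccc(C(F)(F)F)cc3)nc2n1` differs from compound 2 by 4-(trifluoromethyl)phenyl in place of 2,5-dichlorophenyl on a saturated chain carbon bound to a sulfur.

For the measured compounds named here, one measured step bears on this change, made at the same place: an at least 1.1-fold lower number from compound 1 to compound 2 (0.05 log units; that floor lies within the scatter). On that step, no change beyond the scatter is expected in this assay, and compound 3 may well be reported only as a limit. The expected step is a 1.0-fold higher number from compound 2 to compound 3 (0.01 log units; within the scatter). For compound 3 the estimated value is 90000 nM, with an expected range of 45000 nM to 180000 nM.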

Compound 3, half-maximal inhibitory concentration: 17300 nM
Beside the measured number, compound 3's estimate is 5.2-fold (0.72 log units) above it, and the stated range ends above it.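

In this assay, among the compounds shown here, the place on a saturated chain carbon bound to a sulfur now proves able to shift the read-out beyond the scatter, with a 5.1-fold lower number from compound 2 to compound 3 (0.70 log units; beyond the scatter) as the first step here with two true numbers at its ends. The change from 3-chloro-4-fluorophenyl to 4-(trifluoromethyl)phenyl points the same way, with an at least 5.7-fold lower number from compound 1 to compound 3 (0.76 log units; beyond the scatter) as a floor only. Compound 1 stands at a limit of the assay and not at a number: the limit of > 100000 nM in this assay, at which 1 of the 3 values shown sits.

The compounds shown do not separate the entry of trifluoromethyl from the departure of the two chlorines, and they give no step for 4-(trifluoromethyl)phenyl against a plain phenyl. As far as these compounds go, how an amine or a carboxylic acid on this phenyl ring, or a longer chain in place of the benzyl, would read in this assay remains open.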